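Swapping trifluoromethoxy for trifluoroacetyl on the aniline ring

This account rests on a few compounds, and the source may have more. Where it says the series, first, only, none or still open, it means among the compounds named here.

Compound 1 `CN(C)CC[C@H](CSc1ccccc1)Nc1ccc(S(=O)(=O)NC(=O)c2ccc(N3CCN(Cc4ccccc4-c4ccc(Cl)cc4)CC3)cc2)cc1OC(F)(F)F`: < 1 nM
Compound 2 `O=C(NS(=O)(=O)c1ccc(NCCSc2ccccc2)c([N+](=O)[O-])c1)c1ccc(N2CCN(Cc3ccccc3-c3ccc(Cl)cc3)CC2)cc1`: < 1 nM

In an assay on isolated protein for displacement of a labelled ligand from Apoptosis regulator Bcl-2 (Homo sapiens), read by fluorescence polarization (a lower number here means a stronger inhibitor, a higher number a weaker inhibitor), compound 1 gives < 1 nM, which is a limit of the assay rather than a number. Compound 2 likewise gives < 1 nM in this assay, again a limit. Compound 1 therefore stands at the floor of what is shown, where (the limit of < 1 nM in this assay, at which 2 of the 2 values shown sit). Compound 3 `CN(C)CC[C@H](CSc1ccccc1)Nc1ccc(S(=O)(=O)NC(=O)c2ccc(N3CCN(Cc4ccccc4-c4ccc(Cl)cc4)CC3)cc2)cc1C(=O)C(F)(F)F` differs from compound 1 by (trifluoromethyl)carbonyl in place of trifluoromethoxy on an aromatic carbon. Within the data shown here, with both known values resting on the same limit, no measured step guides the direction, and no step beyond the scatter is expected. Compound 3 is accordingly estimated at 1 nM in this assay, between 0.3 nM and 5 nM, an expected step of a number no lower from compound 1 to compound 3 (the limit leaves the size open).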

Compound 3, inhibition constant: < 1 nM
Compound 3: a limit, no number; the forecaster's own chance of this, stated with the estimate: 55%; the middle value lies on the limit itself.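

No step can be read from compound 1 to compound 3, because both values are limits: the limit of < 1 nM in this assay, at which 3 of the 3 values shown sit. The compounds shown leave open whether (trifluoromethyl)carbonyl in place of trifluoromethoxy changes the result in this assay at all.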